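Adding a Vinyl Group to a Weak Sugar-Derived Inhibitor

The source may report more compounds than this note shows. Statements on the series, on what has been measured and on what is new or still open speak of the compounds shown alone.

Three compounds sharing a core decorated with benzyl ether groups have been tested in a functional assay on HeLa cells (Homo sapiens) for antiproliferative activity, read by sulforhodamine B assay; a lower number here means a stronger inhibitor of growth, a higher number a weaker inhibitor of growth. Compound 1, `c1ccc(COC[C@H]2OCC[C@@H](OCc3ccccc3)[C@@H]2OCc2ccccc2)cc1`, gives 33300 nM in this assay. Compound 3, `CCC[C@@H]1O[C@H](COCc2ccccc2)[C@@H](OCc2ccccc2)[C@H](OCc2ccccc2)[C@H]1O`, gives 18900 nM. Compound 2, `CC(=O)O[C@@H]1[C@@H](OCc2ccccc2)[C@H](OCc2ccccc2)[C@@H](COCc2ccccc2)O[C@H]1C`, yields only a limit in this assay, > 50000 nM, rather than a number. As far as these compounds go, compound 2 therefore stands at the limit of > 50000 nM in this assay, at which 1 of the 3 values shown sits, and how far beyond it the true value lies is unknown.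

The new compound 4, `C=CC[C@@H]1O[C@H](COCc2ccccc2)[C@@H](OCc2ccccc2)[C@H](OCc2ccccc2)[C@H]1OC(C)=O`, differs from compound 2 in a single place: vinyl in place of hydrogen on a saturated chain carbon bound to a saturated ring carbon. Cut one bond further out, the same change reads methyl to allyl. Among the compounds with values here, no pair of measured compounds differs in exactly one place, so no measured step can guide the size of this one; the only anchors are the weak growth inhibition of compound 1 with 33300 nM and of compound 3 with 18900 nM, both carrying a small chain on the same kind of core. Given that compound 2 sits at a limit, the step from compound 2 to compound 4 is expected to be small, an at least 1.4-fold lower number from compound 2 to compound 4 (0.15 log units; that floor lies within the scatter), with no confident direction beyond the scatter. Compound 4 is accordingly estimated at 35000 nM, with a likely range from 12000 nM to 100000 nM.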

Compound 4, concentration for 50% growth inhibition: > 50000 nM
Compound 4 was reported as a limit; the forecaster's own chance of this, stated with the estimate: 40%; middle value at least 1.4-fold (0.15 log units) away from the limit.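

Compound 2 and compound 4 are both reported only as limits in this assay, so the size of the step between them cannot be read: the limit of > 50000 nM in this assay, at which 2 of the 4 values shown sit.

The compounds shown leave open whether vinyl in place of hydrogen changes growth inhibition at all, and how far past the limit the true value of either compound lies.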